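A few compounds are considered here, and "the series" means these few. Any claim that something is new, unique, unknown or untested is made for them only; others in the source may bear on it.

Compound 1 `COc1cc(Br)cc(/C=C/C(=O)c2ccccc2)c1O` and compound 2 `COc1cc(Br)cc(/C=C/C(=O)c2ccc(Cl)cc2)c1O` share one core and differ only in that compound 2 carries chloro in place of hydrogen on an aromatic carbon. In a functional assay on MCF7 cells (Homo sapiens) for antiproliferative activity, read by sulforhodamine B assay, with a stated time of 72 h, tested at 10 uM (on this read-out higher numbers stand for a weaker effect at the one concentration tested and lower numbers for a stronger effect), compound 1 gives 67%, and compound 2 gives 53.3%, so the step of a number 13.7 percentage points lower from compound 1 to compound 2 (beyond the scatter) runs toward a stronger effect at the one concentration tested. Compound 3 `COC(=O)C1=C(N)Oc2ccc(Br)cc2C1CC(=O)c1ccccc1` rests on another core; how that core differs from the core of compound 1 is not broken down here. In this assay compound 3 gives 107%, the highest of the three numbers and beyond the scatter above both compound 1 and compound 2. Compound 4 `COC(=O)C1=C(N)Oc2ccc(Br)cc2C1CC(=O)c1ccc(Cl)cc1` stands to compound 3 as compound 2 stands to compound 1: it carries chloro in place of hydrogen on an aromatic carbon, the same change at the same place. Whether the earlier step carries over to the new core is not known from the two pairs alone. In this assay the expected step is a number 10 percentage points lower from compound 3 to compound 4 (within the scatter), set a little smaller than the measured one because compound 3 gives 107%, a number that already signals little effect. Compound 4 is therefore estimated to give 97%, between 82% and 112%.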

Compound 4, a percentage reported as activity, at one concentration (the size of the read-out at that concentration, not a potency): 67.6%
Compound 4: the middle estimate sits 29.4 percentage points above what was measured; the whole stated range lies above it.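

On the core of compound 3, the change from phenyl to 4-chlorophenyl gives in this assay a number 39.4 percentage points lower from compound 3 to compound 4 (beyond the scatter) and so runs in the same direction as on the core of compound 1, toward a stronger effect at the one concentration tested. The size of the step does not carry over from one core to the other: the same change on two cores in this assay, a number 13.7 percentage points lower (beyond the scatter) from compound 1 to compound 2 and a number 39.4 percentage points lower (beyond the scatter) from compound 3 to compound 4, 25.7 percentage points apart, beyond the scatter of two such steps. With a single pair on each core, this shows a shared direction for these two pairs only; it does not show that the direction would hold on any further core, and it does not explain why the two steps differ in size.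

The compounds shown leave open whether another group in the same place, such as fluoro, methoxy or an amine, would move the number in the same way on both cores. They also leave open whether the step would survive if the methyl ester of compound 3 and compound 4 gave way to a carboxylic acid or an amide.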